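This account rests on a few compounds, and the source may have more. Where it says the series, first, only, none or still open, it means among the compounds named here.

Measured so far in an ADME assay on cells (Fibroblast, Homo sapiens) for cytotoxicity, with a stated time of 48 h; on this read-out higher numbers stand for weaker inhibition and lower numbers for stronger inhibition:
- compound 1 `COc1cc(OC)c(C(=O)/C=C/c2ccc(Cl)cc2)c(OC)c1`: a limit only, > 20000 nM
- compound 2 `COc1cccc(/C=C/C(=O)c2c(O)cc(OC)cc2OC)c1`: a limit only, > 20000 nM
- compound 3 `COc1cc(OC)c(C(=O)/C=C/c2ccc(F)cc2)c(OC)c1`: a limit only, > 20000 nM

Compound 1 stands at the limit of this assay; no number is known for it, and the same holds for every other compound measured in this assay. The move to compound 4 `COc1cc(OC)c(C(=O)/C=C/c2ccccc2OC)c(OC)c1` is 2-methoxyphenyl in place of 4-chlorophenyl on a double-bonded chain carbon bound to a double-bonded chain carbon. For the measured compounds named here, the only measured step that touches the same part of the shared core is a step that the two limits leave unreadable from compound 1 to compound 3, and it cannot be read because of the limit of > 20000 nM in this assay, at which 3 of the 3 values shown sit. Going by the values given here, no step measured here therefore shows any direction or size for a change at this position; compound 2, which carries a different change on the other ring, also sits at the limit. The expected outcome for compound 4 is that it too remains at the limit, so the estimated step is a step that the limit leaves unreadable from compound 1 to compound 4, no step beyond the scatter. Compound 4 is expected to give 30000 nM in this assay, with a range from 10000 nM to 100000 nM.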

Compound 4, half-maximal inhibitory concentration: 8200 nM
Compound 4: the middle estimate sits 3.7-fold (0.56 log units) above what was measured; the whole stated range lies above it.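

For the compounds shown here, replacing the aryl group on this double-bonded chain carbon with 2-methoxyphenyl gives the only readable change at this position in this assay, with an at least 2.4-fold lower number from compound 1 to compound 4 (0.38 log units; beyond the scatter) and with an at least 2.4-fold lower number from compound 3 to compound 4 (0.38 log units; beyond the scatter) as the two steps. From the compounds shown here alone, both steps are open-ended, so they fix a direction and a smallest size, and the full size stays unknown. The 2-methoxyphenyl group thus brings compound 4 within the measurable range of this assay, whereas the step between the 4-chlorophenyl and 4-fluorophenyl compounds cannot be read: the limit of > 20000 nM in this assay, at which 3 of the 4 values shown sit.

The compounds shown do not separate the effect of the methoxy group itself from that of its place on the ring. Going by these compounds, how an amine or a carboxylic acid on this phenyl ring would read also stays open.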